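Methoxy on the phenyl ring of compound 3

The source may report more compounds than this note shows. Statements on the series, on what has been measured and on what is new or still open speak of the compounds shown alone.

- Compound 1 `C=C/C=C\[C@H](C)[C@H](OC(N)=O)[C@@H](C)[C@H](O)[C@@H](C)C/C(C)=C\[C@H](C)[C@@H](O)[C@@H](C)/C=C\CCc1cccc(Cl)c1`: 380 nM
- Compound 2 `C=C/C=C\[C@H](C)[C@H](OC(N)=O)[C@@H](C)[C@H](O)[C@@H](C)C/C(C)=C\[C@H](C)[C@@H](O)[C@@H](C)/C=C\CCc1sccc1C`: 370 nM
- Compound 3 `C=C/C=C\[C@H](C)[C@H](OC(N)=O)[C@@H](C)[C@H](O)[C@@H](C)C/C(C)=C\[C@H](C)[C@@H](O)[C@@H](C)/C=C\CCc1ccccc1`: 350 nM

In a functional assay on SK-OV-3 cells (Homo sapiens) for cytotoxicity (on this read-out higher numbers stand for weaker inhibition and lower numbers for stronger inhibition), compound 3 gives 350 nM, within the scatter of the other two compounds. Compound 4 `C=C/C=C\[C@H](C)[C@H](OC(N)=O)[C@@H](C)[C@H](O)[C@@H](C)C/C(C)=C\[C@H](C)[C@@H](O)[C@@H](C)/C=C\CCc1cccc(OC)c1` differs from it by one change: methoxy in place of hydrogen on an aromatic carbon. The closest evidence is a swap of chloro for hydrogen on an aromatic carbon, a 1.1-fold lower number from compound 1 to compound 3 (0.04 log units; within the scatter). Exchanging the aromatic group itself gave a 1.1-fold lower number from compound 2 to compound 3 (0.02 log units; within the scatter) and a 1.0-fold lower number from compound 1 to compound 2 (0.01 log units; within the scatter). Going by the values given here, all three steps stay within the scatter, although no methoxy compound has been measured yet. The expected step is a 1.0-fold higher number from compound 3 to compound 4 (0.01 log units; within the scatter), with no direction expected beyond the scatter. Compound 4 is estimated at 360 nM, with an expected range of 200 nM to 650 nM.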

Compound 4, half-maximal inhibitory concentration: 370 nM
Compound 4: middle estimate off by 1.0-fold (0.01 log units), on the low side; the measured number falls inside the stated range.
By their numbers in this assay, from the lowest: compounds 3, 2, 4 and 1 (each within the scatter of the next).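

Adding methoxy to the phenyl ring gives a 1.1-fold higher number from compound 3 to compound 4 (0.02 log units; within the scatter) in this assay, so this position now has an oxygen-bearing group alongside hydrogen and chloro with no shift beyond the scatter. Direct exchanges agree: methoxy for chloro gives a 1.0-fold lower number from compound 1 to compound 4 (0.01 log units; within the scatter), and 3-methoxyphenyl for 3-methylthiophen-2-yl gives no change at the digits printed from compound 2 to compound 4 (within the scatter). No supporting measurement is available to explain why the number stays flat. Still open, on these data alone, is whether an amine or a carboxylic acid on this ring, or a longer chain in place of the phenethyl link, would move the number beyond the scatter.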